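A few compounds are considered here, and "the series" means these few. Any claim that something is new, unique, unknown or untested is made for them only; others in the source may bear on it.

Measured so far in a functional assay on DLD-1 cells (Homo sapiens) for antiproliferative activity, read by CellTiter-Glo, with a stated time of 72 h; on this read-out higher numbers stand for weaker inhibition and lower numbers for stronger inhibition:
Compound 1 `COc1ccccc1-c1ccc(S(=O)(=O)N2CCC(N3CCC(C)CC3)CC2)cc1` gives 26 nM.
Compound 2 `CC1CCN(C2CCN(S(=O)(=O)c3ccc(-c4ccccc4)cc3)CC2)CC1` gives 258 nM.
Compound 3 `CC1CCN(C2CCN(S(=O)(=O)c3ccc(-c4ccc(Cl)cc4)cc3)CC2)CC1` gives 105 nM.

Compound 3 stands second highest of these three in this assay, between compound 2, reached by a 2.5-fold lower number from compound 2 to compound 3 (0.39 log units; beyond the scatter), and compound 1, from which a 4.0-fold higher number from compound 1 to compound 3 (0.61 log units; beyond the scatter) leads to it. Compound 4 `CC1CCN(C2CCN(S(=O)(=O)c3ccc(OC(F)(F)F)cc3)CC2)CC1` differs from compound 3 by trifluoromethoxy in place of 4-chlorophenyl on an aromatic carbon. Within the data shown here, no measured step covers this change, since all three measured compounds keep an aromatic ring at this place: a 9.9-fold higher number from compound 1 to compound 2 (1.00 log units; beyond the scatter) and a 2.5-fold lower number from compound 2 to compound 3 (0.39 log units; beyond the scatter) only vary what that ring carries, and a 4.0-fold higher number from compound 1 to compound 3 (0.61 log units; beyond the scatter) exchanges one such ring for another. The expectation for compound 4 therefore rests on little, and a rise beyond the scatter is estimated as a 4.8-fold higher number from compound 3 to compound 4 (0.68 log units; beyond the scatter). Compound 4 is expected at 500 nM, within 100 nM to 3000 nM.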

Compound 4, half-maximal inhibitory concentration: 16 nM
Beside the measured number, compound 4's estimate is 31-fold (1.49 log units) above it; the whole stated range lies above it.
By their numbers in this assay, from the lowest: compounds 4 and 1 (each within the scatter of the next); then compound 3; then compound 2.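

In this assay an aromatic ring at this place proves dispensable: trifluoromethoxy, which has no ring, gives a 6.6-fold lower number from compound 3 to compound 4 (0.82 log units; beyond the scatter) and a 16-fold lower number from compound 2 to compound 4 (1.21 log units; beyond the scatter). Against the 2-methoxyphenyl group the change gives a 1.6-fold lower number from compound 1 to compound 4 (0.21 log units; within the scatter), so trifluoromethoxy matches the best ring-bearing compound shown, and compound 4 and compound 1 hold no order. No evidence on the reason for this is at hand. Trifluoromethoxy is the only group without a ring at this place, so it stays open whether trifluoromethyl or ethoxy would do the same.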